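The compounds below may be only part of what the source reports. "The series", "measured", "known", "first", "only" and "open" are said of these compounds alone.

Working notes on the series in an in vitro ADME assay on microsomes from liver (Homo sapiens) for metabolic stability, tested at 0.2 uM; on this read-out higher numbers stand for fast clearance and lower numbers for slow clearance.

Of the compounds shown here, three carry numbers so far. Compound 1, `COCCOCCCCc1[nH]c2ccccc2c(=O)c1C`, gives 45 mL/min/kg. Compound 2, `Cc1c(COc2cccc(OCC3CCOCC3)c2)[nH]c2ccc(-c3cccnc3)cc2c1=O`, gives 756 mL/min/kg. Compound 3, `Cc1c(COc2cccc(OCC3CCOCC3)n2)[nH]c2ccccc2c1=O`, gives 770 mL/min/kg. On these numbers compound 2 stands second highest of the three: its nearest neighbour is compound 3, whose number lies within the scatter of repeated measurements, so nothing is said about which of the two clears faster; the furthest is compound 1, whose number is lower by a margin beyond the scatter.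

The next compound, compound 4, `Cc1c(COc2cccc(OCC3CCOCC3)c2)[nH]c2ccc(Cl)cc2c1=O`, has not yet been measured in this assay. It differs from compound 2 in one place: chloro in place of pyridin-3-yl on an aromatic carbon. The pyridin-3-yl leaves and a chloro enters, on an aromatic carbon of a six-membered aromatic ring of carbon only, part of a fused or bridged system of two rings; the rest of compound 2 is kept.

Among the compounds with values here, no measured pair in the set isolates this change, so the expectation rests on compound 2 alone, 756 mL/min/kg, with compound 3 at 770 mL/min/kg showing that the kept part of the structure is found with high numbers. The step from compound 2 to compound 4 is expected to be small, a 1.3-fold lower number from compound 2 to compound 4 (0.10 log units; within the scatter), and not clearly beyond the scatter in either direction. Compound 4 is therefore estimated at 600 mL/min/kg, within a range from 250 mL/min/kg to 1300 mL/min/kg.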

Compound 4, clearance: > 1000 mL/min/kg
Compound 4: only a limit was reported; the forecaster's own chance of this, stated with the estimate: 5%; middle value at least 1.6-fold (0.22 log units) away from the limit.
By their numbers in this assay, from the lowest: compound 1; then compounds 2 and 3 (each within the scatter of the next). At a limit, above all of these: compound 4.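

Chloro in place of pyridin-3-yl, on an aromatic carbon meta to a fused ring and para to a fused ring, is the first change in the series that can be read in one place, and in this assay it gives an at least 1.3-fold higher number from compound 2 to compound 4 (0.12 log units; that floor lies within the scatter). The reading for compound 4 is a limit of the assay and not a number, so the true size of this step remains unfixed: the limit of > 1000 mL/min/kg in this assay, at which 1 of the 4 values shown sits.

What the step does show is narrower: with the pyridin-3-yl ring gone and a single chlorine in its place, no lower number appears on this read-out, so the high clearance of compound 2 does not depend on keeping that ring at this position.

On these data alone, since the floor of the step lies within the scatter, it remains open how far compound 4 really stands from compound 2, and whether the two differ at all. Also open, as far as these compounds go, is how this position responds to a group of another kind, such as an amine or a carboxylic acid, with the rest of compound 2 kept.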